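This account rests on a few compounds, and the source may have more. Where it says the series, first, only, none or still open, it means among the compounds named here.

Measured compounds:
- compound 1 `CN1Cc2ccc(OCc3ccc([N+](=O)[O-])cc3)cc2[C@@H](O)C1`: in an ADME assay on Vero cells (Chlorocebus sabaeus) for cytotoxicity, read by sulforhodamine B assay, with a stated time of 72 h (on this read-out lower numbers stand for stronger inhibition and higher numbers for weaker inhibition), compound 1 gives > 50000 nM, a limit of the assay.
- compound 2 `CN1Cc2ccc(OCCC3CCCCC3)cc2[C@@H](O)C1`: in this assay compound 2 gives > 50000 nM, likewise a limit of the assay.

Within the data shown here, compound 2 therefore stands at the limit, as does the only other value shown, which is what the limit of > 50000 nM in this assay, at which 2 of the 2 values shown sit, records. Compound 3 `CN1Cc2ccc(OCc3ccc(Br)cc3)cc2[C@@H](O)C1` differs from compound 2 by 4-bromophenyl in place of cyclohexylmethyl on a saturated chain carbon bound to an oxygen on an aromatic ring. Among the measured compounds shown here, no measured step covers this change, and no shift beyond the usual scatter in this assay is expected in either direction. Compound 3 is expected to sit at the limit as well, with an estimate of 80000 nM and a range of 30000 nM to 300000 nM. The expected step that the limit leaves unreadable from compound 2 to compound 3 is thus none beyond the scatter.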

Compound 3, half-maximal inhibitory concentration: 37000 nM
Estimate against measurement, compound 3: 2.2-fold (0.33 log units) above; the range from low to high includes it.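

In this assay, compound 3 gives a measured number, 37000 nM, rather than a limit. Placing 4-bromophenyl in place of cyclohexylmethyl gives an at least 1.3-fold lower number from compound 2 to compound 3 (0.13 log units; that floor lies within the scatter), and bromo in place of nitro on an aromatic carbon gives an at least 1.3-fold lower number from compound 1 to compound 3 (0.13 log units; that floor lies within the scatter). Neither floor shows a change beyond the scatter, and the true size of each step stays unreadable because the other two compounds sit at a limit: the limit of > 50000 nM in this assay, at which 2 of the 3 values shown sit.

Going by these compounds, whether chloro or an amine in place of bromo on the aromatic carbon would also give a measured number remains open.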